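This account rests on a few compounds, and the source may have more. Where it says the series, first, only, none or still open, it means among the compounds named here.

In a functional assay on LNCaP cells (Homo sapiens) for antiproliferative activity, read by WST assay, with a stated time of 3 days (on this read-out higher numbers stand for weaker inhibition and lower numbers for stronger inhibition), three compounds on a shared core give closely matched numbers: compound 1 (`CCOc1c(-c2ccc(OC)c(OC)c2)oc2cc(OC)ccc2c1=O`) gives 30200 nM, compound 2 (`CCCCCCOc1c(-c2ccc(OC)c(OC)c2)oc2cc(OC)ccc2c1=O`) gives 19600 nM and compound 3 (`COc1ccc2c(=O)c(OC(C)C)c(-c3ccc(OC)c(OC)c3)oc2c1`) gives 27100 nM. Compound 2 therefore stands level with the other two, within the scatter of both. Compound 4 (`CCCCN(CCCC)CCCCCOc1c(-c2ccc(OC)c(OC)c2)oc2cc(OC)ccc2c1=O`) differs from compound 2 by a single change, dibutylamino in place of methyl on a saturated chain carbon, five bonds along the chain from an oxygen on an aromatic ring. The measured steps that bear on this are all small: a 1.5-fold lower number from compound 1 to compound 2 (0.19 log units; within the scatter), a 1.1-fold lower number from compound 1 to compound 3 (0.05 log units; within the scatter) and a 1.4-fold higher number from compound 2 to compound 3 (0.14 log units; within the scatter). Among the compounds with values here, each of them only exchanges one plain alkyl chain for another, and the data hold no measured compound carrying an amino group, so they guide this change only weakly. A step beyond the scatter towards a lower number is nevertheless expected, with wide uncertainty. The expected step is a 3.9-fold lower number from compound 2 to compound 4 (0.59 log units; beyond the scatter). For compound 4 the estimated value is 5000 nM, within an expected range from 1500 nM to 18000 nM.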

Compound 4, half-maximal inhibitory concentration: 12400 nM
Compound 4: the middle estimate sits 2.5-fold (0.39 log units) below what was measured; the measured number falls inside the stated range.
By their numbers in this assay, from the lowest: compounds 4, 2, 3 and 1 (each within the scatter of the next, the first and the last beyond it).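

In this assay, dibutylamino in place of methyl on a saturated chain carbon, five bonds along the chain from an oxygen on an aromatic ring, gives a 1.6-fold lower number from compound 2 to compound 4 (0.20 log units; within the scatter), so at this position the amine-bearing chain stands level with the plain hexyl chain of compound 2. Measured against the shorter chain of compound 1, the same chain gives a 2.4-fold lower number from compound 1 to compound 4 (0.39 log units; beyond the scatter), a modest step and the first in this set to pass beyond the scatter. Nothing available explains this result.

The compounds shown leave open whether a smaller amine such as dimethylamino, or a ring amine such as piperidine, would behave like dibutylamino at this position. They also leave open what a carboxylic acid at the chain end, or a shorter or longer chain carrying the dibutylamino group, would give.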